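The source may hold more compounds than are shown below. What is called first, only, known or untested is meant among the compounds shown, and "the series" means these compounds.

Compound 1, `CCOCC(COCC)Nc1nc(C)nc2c(-c3ccc(OC)cc3C)c(C)nn12`: 19.3 nM
Compound 2, `CCCN(C)c1nc(C)nc2c(-c3c(C)cc(OC)cc3OC)c(C)nn12`: 6.48 nM

Both were tested in an assay on cell membranes for displacement of a labelled ligand from corticotropin-releasing factor receptor 1 (Rattus norvegicus); on this read-out lower numbers stand for stronger inhibition and higher numbers for weaker inhibition. Of these two numbers, compound 1 has the higher one, and compound 2 the lower, a gap that goes beyond the usual scatter. Compound 3, `COCC(COC)Nc1nc(C)nc2c(-c3ccc(OC)cc3C)c(C)nn12`, has not yet been measured; it differs from compound 1 by 2-methoxy-1-(methoxymethyl)ethyl in place of 2-ethoxy-1-(ethoxymethyl)ethyl on a nitrogen on an aromatic ring. The two side chains at that nitrogen are alike in shape and in their counted features, so a small step, or none beyond the scatter, is expected: an estimated change of a 1.1-fold higher number from compound 1 to compound 3 (0.06 log units; within the scatter). Compound 3 is thus expected to give about 22 nM in this assay, likely between 9 nM and 55 nM.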

Compound 3, half-maximal inhibitory concentration: 9.7 nM
Compound 3: the middle estimate sits 2.3-fold (0.36 log units) above what was measured; the measured number falls inside the stated range.
By their numbers in this assay, from the lowest: compounds 2, 3 and 1 (each within the scatter of the next, the first and the last beyond it).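

At this nitrogen, the 7-heavy-atom 2-methoxy-1-(methoxymethyl)ethyl chain replaces the 9-heavy-atom 2-ethoxy-1-(ethoxymethyl)ethyl chain with a 2.0-fold lower number from compound 1 to compound 3 (0.30 log units; within the scatter) in this assay, so this read-out cannot tell the two chains apart. Both chains have 2 hydrogen-bond acceptors, so the pair varies the chain's size but not that count. Nothing measured here explains the result. From the compounds shown here alone, whether a chain with no ether oxygen, such as a plain butyl, would perform alike remains open. So does the effect of ending the chain in an amine or a carboxylic acid.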